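Cyanoethenyl anilino series: from compound 3 to compound 4

This account rests on a few compounds, and the source may have more. Where it says the series, first, only, none or still open, it means among the compounds named here.

Three members of this series have been through an ADME assay on MT4 cells (Homo sapiens) for cytotoxicity, read by MTT assay, with a stated time of 5 days; on this read-out lower numbers stand for higher toxicity in this test and higher numbers for lower toxicity in this test. Compound 1 `COc1cc2nc(SCC(=O)Nc3ccc(S(N)(=O)=O)cc3)nc(Nc3c(Cl)cc(/C=C/C#N)cc3Cl)c2cc1OC` gives 116000 nM. Compound 2 `COc1cc2nc([S+]([O-])CC(=O)Nc3ccc(F)cc3)nc(Nc3c(C)cc(/C=C/C#N)cc3C)c2cc1OC` gives 27400 nM. Compound 3 `COc1cc2nc([S+]([O-])CC(=O)Nc3ccc(C(F)(F)F)cc3)nc(Nc3c(C)cc(/C=C/C#N)cc3C)c2cc1OC` gives 52200 nM. Going by the values given here, the one single-point step among them is the change of fluoro to trifluoromethyl on an aromatic carbon, which gave a 1.9-fold higher number from compound 2 to compound 3 (0.28 log units; within the scatter). Compound 3 therefore holds the second highest of the three numbers, with compound 2 within the scatter of it and compound 1 the furthest away, beyond the scatter.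

Compound 4 `COc1cc2nc([S+]([O-])CC(=O)Nc3ccc(C(F)(F)F)cc3)nc(Nc3c(Cl)cc(/C=C/C#N)cc3Cl)c2cc1OC` has not yet been measured. It differs from compound 3 in one place: a group of 12 heavy atoms (9 carbon, 1 nitrogen, 2 chlorine; one six-membered aromatic ring of carbon only) in place of a group of 12 heavy atoms (11 carbon, 1 nitrogen; one six-membered aromatic ring of carbon only), on a nitrogen on an aromatic ring.

Among the compounds with values here, no measured step bears directly on this change. Compound 1 carries the same chlorine-bearing group on the aromatic nitrogen, but it also differs from compound 3 elsewhere, so its value can only be read as a loose pointer toward higher numbers. Within the data shown here, the single step from compound 2 to compound 3 concerns a different position and lay within the scatter. The expected step of a 1.3-fold higher number from compound 3 to compound 4 (0.13 log units; within the scatter) for compound 4 is accordingly small, leaning upward. Compound 4 is estimated at 70000 nM, within a range from 30000 nM to 160000 nM.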

Compound 4, half-maximal cytotoxic concentration: 22000 nM
For compound 4 the middle estimate is 3.2-fold (0.50 log units) above the measured one; measured number below the stated range.
By their numbers in this assay, from the lowest: compounds 4, 2 and 3 (each within the scatter of the next, the first and the last beyond it); then compound 1.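

Working notes after compound 4. In this assay, the group entering on a nitrogen on an aromatic ring in place of 4-(2-cyanoethenyl)-2,6-dimethylphenyl gives a 2.4-fold lower number from compound 3 to compound 4 (0.38 log units; beyond the scatter), the first step read at this place, and it shows that this place can move the number beyond the scatter, towards higher toxicity in this test. The two groups match in every computed count of rings, double and triple bonds, hydrogen-bond donors and acceptors and charge, and in heavy atoms overall, and they part only in composition, with 9 carbon and 2 chlorine against 11 carbon. No measurement on hand accounts for the size or direction of this step.

Going by these compounds, this place rests on a single pair, so it stays open whether the step carries over to a fluoro partner on the aromatic carbon or to a sulfide in place of the sulfoxide. On these data alone, how bromine or methoxy in place of the chlorine would read, or an amine in place of the trifluoromethyl, also remains open.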